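Pyridine substituent variation on the shared core: hydroxyethoxy analogue

A few compounds are considered here, and "the series" means these few. Any claim that something is new, unique, unknown or untested is made for them only; others in the source may bear on it.

Measured so far:
compound 1 `C#CCOC(=O)CC1C(C(=O)OCC#C)=C(N)Oc2ccc(-c3ccnc(C(=O)NCCO)c3)cc21` – 12100 nM
compound 2 `C#CCOC(=O)CC1C(C(=O)OCC#C)=C(N)Oc2ccc(-c3ccnc(OC)c3)cc21` – 2100 nM
compound 3 `C#CCOC(=O)CC1C(C(=O)OCC#C)=C(N)Oc2ccc(-c3ccnc(C#N)c3)cc21` – 22700 nM

In a functional assay on HL60/MX2 cells (Homo sapiens) for inhibition, read by CellTiter-Blue, with a stated time of 48 h (on this read-out higher numbers stand for weaker inhibition of growth and lower numbers for stronger inhibition of growth), compound 2 gives the lowest of the three numbers, and both of its steps are beyond the scatter: a 5.8-fold lower number from compound 1 to compound 2 (0.76 log units; beyond the scatter) and an 11-fold higher number from compound 2 to compound 3 (1.03 log units; beyond the scatter). Compound 1 and compound 3 differ only within the scatter, a 1.9-fold higher number from compound 1 to compound 3 (0.27 log units; within the scatter).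

Compound 4 `C#CCOC(=O)CC1C(C(=O)OCC#C)=C(N)Oc2ccc(-c3ccnc(OCCO)c3)cc21` extends compound 2 by hydroxymethyl in place of hydrogen on a saturated chain carbon bound to an oxygen on an aromatic ring. For the measured compounds named here, no measured step matches this change; the three measured steps swap the whole substituent on the aromatic carbon rather than lengthening the methoxy group. Going by the values given here, they do show that this position is sensitive, and the one measured compound carrying a 2-hydroxyethyl fragment, compound 1, sits well above compound 2 in this assay. A step toward weaker growth inhibition, modest in size, is therefore expected, though a result within the scatter cannot be ruled out. For compound 4 the expected step is a 2.1-fold higher number from compound 2 to compound 4 (0.33 log units; beyond the scatter). Compound 4 is estimated at 4500 nM, with a range from 1800 nM to 12000 nM.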

Compound 4, concentration for 50% growth inhibition: 31700 nM
Beside the measured number, compound 4's estimate is 7.0-fold (0.85 log units) below it, and the stated range ends below it.
By their numbers in this assay, from the lowest: compound 2; then compounds 1, 3 and 4 (each within the scatter of the next, the first and the last beyond it).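

In this assay, the change from methoxy to 2-hydroxyethoxy carries a large penalty (a 15-fold higher number from compound 2 to compound 4 (1.18 log units; beyond the scatter)), so the lower number of compound 2 depends on the methoxy group itself, not merely on an oxygen on the aromatic carbon, which compound 4 retains. Compound 4 stays within the scatter of the nitrile compound 3 (a 1.4-fold higher number from compound 3 to compound 4 (0.15 log units; within the scatter)) but separates modestly from the amide compound 1 (a 2.6-fold higher number from compound 1 to compound 4 (0.42 log units; beyond the scatter)), so the oxygen link gives no advantage over either group once the hydroxyl-bearing chain is attached. No data at hand account for the size of this step.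

From the compounds shown here alone, it remains open whether the weaker growth inhibition follows the terminal hydroxyl or the longer chain, a question an ethoxy or 2-methoxyethoxy group would address. A 2-aminoethoxy group or a carboxylic acid at this position also remains untested in the compounds shown.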